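Trimethoxyphenyl chalcone analogue: expected growth inhibition

The source may report more compounds than this note shows. Statements on the series, on what has been measured and on what is new or still open speak of the compounds shown alone.

Measured so far:
compound 1 `COc1ccc(C(=O)/C=C/c2cc(-c3cc(OC)c(OC)c(OC)c3)n[nH]2)cc1OC` 2630 nM
compound 2 `COc1cc(-c2cc(/C=C/C(=O)c3ccc(F)c(F)c3)[nH]n2)cc(OC)c1OC` 13900 nM

In a functional assay on HCT-116 cells (Homo sapiens) for inhibition, read by sulforhodamine B assay, with a stated time of 48 h (a lower number here means a stronger inhibitor of growth, a higher number a weaker inhibitor of growth), compound 1 gives 2630 nM, the lowest of the two numbers at hand. Compound 2 sits well away from it: a 5.3-fold higher number from compound 1 to compound 2 (0.72 log units; beyond the scatter) shows that swapping the aryl group on the carbonyl carbon shifts the number by a clear margin, so the carbonyl-side ring is not indifferent.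

Compound 3 `COc1cc(C(=O)/C=C/c2cc(-c3cc(OC)c(OC)c(OC)c3)n[nH]2)cc(OC)c1OC` carries the same shared core as compound 1 and differs only on the carbonyl-side ring: methoxy in place of hydrogen on an aromatic carbon. Among the measured compounds shown here, no measured step exchanges hydrogen for methoxy at this place, so the only guidance is the single step from compound 1 to compound 2, which concerns a different exchange and gives size, not direction.

Compound 3 is therefore expected to stay in the region of compound 1, with the estimate 2000 nM and range 700 nM to 6000 nM, amounting to a 1.3-fold lower number from compound 1 to compound 3 (0.12 log units; within the scatter).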

Compound 3, concentration for total growth inhibition: 2590 nM
Compound 3: the middle estimate sits 1.3-fold (0.11 log units) below what was measured; the measured number falls inside the stated range.
By their numbers in this assay, from the lowest: compounds 3 and 1 (each within the scatter of the next); then compound 2.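

In this assay, methoxy in place of hydrogen on an aromatic carbon of the carbonyl-side ring, ortho to a methoxy group and meta to a large group, gives a 1.0-fold lower number from compound 1 to compound 3 (0.01 log units; within the scatter) and so leaves the number within the scatter. The carbonyl-side ring had already responded to a change of substituents, with a 5.3-fold higher number from compound 1 to compound 2 (0.72 log units; beyond the scatter) in the same assay, but this position accepts one more methoxy without a readable change. The response of this ring therefore depends on which change is made, and no measurement given here bears on the reason.

Going by these compounds, it remains open whether an amine, a hydroxyl or a carboxylic acid at this carbon would also leave the number in place. It is also open which of the two ring positions exchanged between compound 1 and compound 2 accounts for that step.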